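The source may hold more compounds than are shown below. What is called first, only, known or untested is meant among the compounds shown, and "the series" means these compounds.

Measured compounds:

Compound 1 `CCCCCCNS(=O)(=O)NC(=O)Nc1c(C(C)C)cccc1C(C)C` gives 8100 nM in an assay on liver for inhibition of sterol O-acyltransferase 1 (Rattus norvegicus), using microsomes; a higher number here means a weaker inhibitor, a lower number a stronger inhibitor.
Compound 2 `CCCCCCCCN(CCCCCCCC)S(=O)(=O)NC(=O)Oc1c(C(C)C)cccc1C(C)C` gives 58000 nM in this assay.
Compound 3 `CC(C)c1cccc(C(C)C)c1OS(=O)(=O)NC(=O)O[C@@H]1C[C@H](C)CCC1C(C)C` gives 21000 nM in this assay.

All three numbers are high, so none of these compounds is a strong inhibitor. Compound 3 sits in the middle of the three: its number is the second highest. The nearest neighbour is compound 1, whose lower number lies beyond the usual scatter of repeated measurements, and the furthest is compound 2, whose higher number also lies beyond that scatter. Compound 3 is therefore neither the weakest nor the strongest of the set, but it is clearly separated from both of the others.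

Compound 4 `CC(C)c1ccccc1OC(=O)NS(=O)(=O)Oc1c(C(C)C)cccc1C(C)C` has not yet been measured in this assay. It differs from compound 3 in one place: 2-isopropylphenyl in place of 2-isopropyl-5-methylcyclohexyl on an oxygen next to a carbonyl group. A saturated ring carrying two defined stereocentres is exchanged for a flat aromatic ring of nearly the same size, while the rest of the molecule is kept.

For the measured compounds named here, no pair of measured compounds shows what such an exchange does here, so there is no measured step to lean on. With so little to go on, no shift beyond the scatter is expected from compound 3 to compound 4, with the range kept wide on both sides. The expected step of a 1.2-fold lower number from compound 3 to compound 4 (0.09 log units; within the scatter) is therefore small. Compound 4 is estimated at 17000 nM, with a range from 4000 nM to 70000 nM.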

Compound 4, half-maximal inhibitory concentration: > 50000 nM
Compound 4: a limit, no number (the forecaster's own chance of this, stated with the estimate: 10%); middle value at least 2.9-fold (0.46 log units) away from the limit.
By their numbers in this assay, from the lowest: compound 1; then compound 3; then compound 2.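

Replacing 2-isopropyl-5-methylcyclohexyl with 2-isopropylphenyl on an oxygen next to a carbonyl group is the first change in one place among these compounds, and in this assay it brings an at least 2.3-fold higher number from compound 3 to compound 4 (0.37 log units; beyond the scatter), so at this position the aromatic ring goes with a weaker inhibitor than the non-aromatic ring, and the choice of group here clearly matters. Compound 4 reads > 50000 nM, which is a limit of the assay and not a number. On these data alone, how much weaker compound 4 really is stays unknown because the reading stops at that limit: the limit of > 50000 nM in this assay, at which 1 of the 4 values shown sits.

This single pair changes several things at once, as the ring becomes aromatic, one carbon goes and the 2 defined stereocentres disappear, so it cannot say which of these goes with the weaker inhibition. It also leaves open how an unsubstituted cyclohexyl, a plain phenyl or a straight hexyl chain on the same oxygen would compare, and whether any group there could bring the number far below those seen so far.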